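Bromo for trifluoromethyl on a shared core

The source may hold more compounds than are shown below. What is called first, only, known or untested is meant among the compounds shown, and "the series" means these compounds.

Of the compounds shown here, three share one core and have been tested in a functional assay (aorta) with Rattus norvegicus as the target; a lower number here means that less compound is needed, a higher number that more compound is needed for the effect. Compound 1 `C/N=C(/S)C1=CC(C)(C)Oc2ccc([N+](=O)[O-])cc21` gives 1.29 nM. Compound 2 `C/N=C(/S)C1=CC(C)(C)Oc2ccc(S(=O)(=O)c3ccccc3)cc21` gives 19.5 nM. Compound 3 `C/N=C(/S)C1=CC(C)(C)Oc2ccc(C(F)(F)F)cc21` gives 2.19 nM. Among these three numbers, compound 3 stands second highest: its nearest neighbour is compound 1, a step within the scatter, and its furthest is compound 2, a step beyond the scatter. Among the measured compounds shown here, the one step between compounds that differ in a single place, a 1.7-fold higher number from compound 1 to compound 3 (0.23 log units; within the scatter), shows that replacing one group with another on this aromatic carbon left the number within the scatter.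

Compound 4 `C/N=C(/S)C1=CC(C)(C)Oc2ccc(Br)cc21` differs from compound 3 as follows: bromo in place of trifluoromethyl on an aromatic carbon. For the measured compounds named here, no measured step involves a bromo group, so the only guidance comes from compound 3 and compound 1, whose values lie within the scatter of each other; compound 2 shows that a larger group on the same carbon went with a higher number, but the size of that step offers no direct read on a smaller group. The account therefore expects, for compound 4 in this assay, a step of about a 1.4-fold higher number from compound 3 to compound 4 (0.14 log units; within the scatter), not beyond the scatter. Compound 4 is estimated at 3 nM, within a range from 1 nM to 9 nM.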

Compound 4, half-maximal effective concentration: 15.1 nM
The estimate for compound 4 lay 5.0-fold (0.70 log units) below the measured number; the whole stated range lies below it.
By their numbers in this assay, from the lowest: compounds 1 and 3 (each within the scatter of the next); then compounds 4 and 2 (each within the scatter of the next).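

In this assay, the aromatic carbon of the shared core proves sensitive to which group it carries: bromo brings a 6.9-fold higher number from compound 3 to compound 4 (0.84 log units; beyond the scatter), and set against nitro it brings a 12-fold higher number from compound 1 to compound 4 (1.07 log units; beyond the scatter). Among the compounds shown here, the only single-place step known before, a 1.7-fold higher number from compound 1 to compound 3 (0.23 log units; within the scatter), lay within the scatter and gave no sign that an exchange here could move the number beyond it, while compound 4 now sits within the scatter of compound 2 at 19.5 nM, so the higher numbers do not follow group size, with bromo, at one heavy atom, alongside the larger phenylsulfonyl group. Nothing available bears on why bromo parts from trifluoromethyl and nitro at this position.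

The compounds shown leave open where other groups on this carbon would fall, such as chloro, a nitrile, an amine or a carboxylic acid, and so whether nitro and trifluoromethyl are an exception among the groups that can sit here or bromo is. They also leave open whether the same exchange would give a step of similar size on the other carbons of this aromatic ring.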